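The source may hold more compounds than are shown below. What is called first, only, known or untested is meant among the compounds shown, and "the series" means these compounds.

Measured in a functional assay on Ehrlich cells (Mus musculus) for cytotoxicity, read by trypan blue exclusion, with a stated time of 2 h, tested at 25 ug/mL; a higher number here means a stronger effect of the compound at the concentration tested, a lower number a weaker effect:
compound 1 `N#CC1=C(N)N(c2ccc(S(N)(=O)=O)cc2)C2=C(CCCC2)C1c1ccccc1` gives 10%
compound 2 `COc1ccccc1C1C(C#N)=C(N)N(c2ccc(S(N)(=O)=O)cc2)C2=C1CCCC2` gives 40%

Compound 2 stands highest of the two numbers; its nearest is compound 1, with a number 30 percentage points higher from compound 1 to compound 2 (beyond the scatter). Compound 3 `N#CC1=C(N)N(c2ccc(S(N)(=O)=O)cc2)C2=C(CCCC2)C1c1ccc(Cl)cc1Cl` differs from compound 2 by 2,4-dichlorophenyl in place of 2-methoxyphenyl on a saturated ring carbon. For the measured compounds named here, no measured step bears directly on this change. Going by the values given here, the single step known, a number 30 percentage points higher from compound 1 to compound 2 (beyond the scatter), concerns a different substitution and shows only that the group on the saturated ring carbon can move the read-out beyond the scatter. Without a comparable step, the expected step in this assay, a number 10 percentage points lower from compound 2 to compound 3 (within the scatter), is set near none, with a wide range. Compound 3 is therefore estimated at 30%, between 10% and 60%.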

Compound 3, a percentage reported as activity, at one concentration (the size of the read-out at that concentration, not a potency): 50%
Estimate against measurement, compound 3: 20 percentage points below; measured number inside the range.
By their numbers in this assay, from the lowest: compound 1; then compounds 2 and 3 (each within the scatter of the next).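

In this assay, 2,4-dichlorophenyl in place of phenyl on the saturated ring carbon gives a number 40 percentage points higher from compound 1 to compound 3 (beyond the scatter), so a second substituted aryl group at this position clears the scatter. Exchanging 2-methoxyphenyl for 2,4-dichlorophenyl gives a number 10 percentage points higher from compound 2 to compound 3 (within the scatter), so these two groups are not told apart in this read-out. No available measurement accounts for either step.

Open, going by these compounds, is whether both chlorines are needed or one suffices. Also open, on these data alone, is how an aminophenyl or carboxyphenyl group at this position would read.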